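A few compounds are considered here, and "the series" means these few. Any claim that something is new, unique, unknown or untested is made for them only; others in the source may bear on it.

Compound 2 `CCOc1cc(/C=C/C(=O)c2ccncc2)cc(OCC)c1OCC` gives 92 nM in an assay on HEK293 cells for inhibition of cytochrome P450 1A1 (Homo sapiens), read by fluorescence, with stated times of 30 min and 60 min (a higher number here means a weaker inhibitor, a lower number a stronger inhibitor), the lowest of the two numbers in hand; compound 1 `COc1ccc(/C=C/C(=O)c2ccncc2)cc1OC` gives 420 nM in this assay, and the gap between the two lies beyond the usual scatter. Compound 3 `CCOc1cc(/C=C/C(=O)c2ccncc2)cc(OC)c1OCC` differs from compound 2 by hydrogen in place of methyl on a saturated chain carbon bound to an oxygen on an aromatic ring. Going by the values given here, no step between measured compounds that differ in one place is available, so the size of the change can rest only on the two values in hand. A small rise in number is expected, a 1.6-fold higher number from compound 2 to compound 3 (0.21 log units; within the scatter), possibly still within the scatter. Compound 3 is expected to give 150 nM in this assay, between 70 nM and 350 nM.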

Compound 3, half-maximal inhibitory concentration: 65 nM
Estimate against measurement, compound 3: 2.3-fold (0.36 log units) above; measured number below the stated range.
By their numbers in this assay, from the lowest: compounds 3 and 2 (each within the scatter of the next); then compound 1.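

Ethoxy to methoxy at this place gives a 1.4-fold lower number from compound 2 to compound 3 (0.15 log units; within the scatter) in this assay, so removing the methyl from the saturated chain carbon bound to an oxygen on an aromatic ring has no effect that can be resolved from the scatter. On this evidence, compound 2 and compound 3 read as equivalent, and this place accepts either ethoxy or methoxy.

Still open, as far as these compounds go, is whether a longer chain such as butoxy, or an amine, at this place stays in the same range, and whether the remaining ethoxy groups accept the same change. No measurement in hand bears on the reason for this result.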